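This account rests on a few compounds, and the source may have more. Where it says the series, first, only, none or still open, it means among the compounds named here.

Measured so far in a functional assay on KB cells (Homo sapiens) for inhibition, read by MTT assay, with a stated time of 24 h, tested at 10 ug/mL; a lower number here means less inhibition of growth, a higher number more inhibition of growth at the concentration tested:
Compound 1 `O=C(CCCCC(CCSC(=O)c1ccccc1)SC(=O)c1ccccc1)Nc1ccccc1`: 2.67%
Compound 2 `O=C(CCCCC(CCSC(=O)c1ccccc1)SC(=O)c1ccccc1)Nc1ccccc1Cl`: 2.53%

Compound 2 stands level with compound 1, as their two values lie within the scatter of each other. Next comes compound 3 `O=C(CCCCC(CCSC(=O)c1ccccc1)SC(=O)c1ccccc1)Nc1ccc(Cl)cc1`, which has the same atoms as compound 2, joined differently: 4-chlorophenyl in place of 2-chlorophenyl on an amide-type nitrogen. In words, 4-chlorophenyl replaces 2-chlorophenyl on an amide-type nitrogen. For the measured compounds named here, no measured step covers this exact swap. Going by the values given here, the closest evidence is the only structural step measured so far, which gave a number 0.1 percentage points lower from compound 1 to compound 2 (within the scatter). Among the compounds with values here, with only that small step to go on, no shift beyond the scatter is expected in this assay, in either direction. The expected change is a number 0.5 percentage points higher from compound 2 to compound 3 (within the scatter). For compound 3 the estimated value is 3%, with an expected range of 0% to 10%.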

Compound 3, percent growth inhibition at one concentration: 10.6%
Beside the measured number, compound 3's estimate is 7.6 percentage points below it; the measured number lies above the stated range.
By their numbers in this assay, from the lowest: compounds 2, 1 and 3 (each within the scatter of the next).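

In this assay, moving the chlorine from 2-chlorophenyl to 4-chlorophenyl on the amide-type nitrogen gives a number 8.1 percentage points higher from compound 2 to compound 3 (within the scatter) and setting chloro in place of hydrogen as 4-chlorophenyl gives a number 7.9 percentage points higher from compound 1 to compound 3 (within the scatter) for the second comparison. This place on the molecule has now been probed with two chlorine placements, and neither step stands clear of the usual scatter, so neither placement can be told apart from the other or from plain phenyl. Nothing available here offers an explanation for these numbers.

Going by these compounds, what stays open is whether a different group on the amide-type nitrogen, such as 4-methoxyphenyl, 4-aminophenyl or benzyl, would move growth inhibition beyond the scatter. The same question holds for changes elsewhere in the shared core, for instance a longer chain or an acetyl group in place of the benzoyl groups.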